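Compound 3 in the fluoromethyl step: working notes

The source may hold more compounds than are shown below. What is called first, only, known or untested is meant among the compounds shown, and "the series" means these compounds.

compound 1 `NC1=N[C@@]2(c3cc(NC(=O)c4cnc(OCF)cn4)ccc3F)COCC[C@H]2CC1(F)F` in a physicochemical assay for acid dissociation, gives 6.6
compound 2 `C[C@H]1C[C@H]2CC(F)(F)C(N)=N[C@@]2(c2cc(NC(=O)c3cnc(OCF)cn3)ccc2F)CO1` in this assay gives 6.6

Compound 2 stands level with compound 1 at the digits available, and compound 1 is its nearest neighbour. For the measured compounds named here, the one measured step shows no change at the digits printed from compound 1 to compound 2 (within the scatter) for methyl in place of hydrogen on a saturated ring carbon.

Compound 3 `NC1=N[C@@]2(c3cc(NC(=O)c4cnc(OCF)cn4)ccc3F)CO[C@@H](CF)C[C@H]2CC1(F)F` is still to be measured in this assay and differs from compound 2 as follows: fluoro in place of hydrogen on a saturated chain carbon bound to a saturated ring carbon with fluoro in place of hydrogen on a saturated chain carbon bound to a saturated ring carbon. Cut one bond further out, this reads methyl to fluoromethyl.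

Going by the values given here, the methyl step is the only measured guide, and it involves no fluoro group, so the series gives no direct measure of this change. The expected step is a number 0.20 log units lower from compound 2 to compound 3 (within the scatter) and would be a small one in the lower direction, not beyond the scatter. Compound 3 is estimated at 6.4 with a range of 6.1 to 6.7 for this expectation.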

Compound 3, acid dissociation constant: 6.4
Compound 3: middle estimate and measured number agree at the digits printed, within the range that was stated.
By their numbers in this assay, from the lowest: compounds 3, 1 and 2 (each within the scatter of the next).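

In this assay, for the compounds shown here, the series now has its first reading of a fluoro group on the chain at this saturated ring carbon: the record gives a number 0.20 log units lower from compound 2 to compound 3 (within the scatter) for fluoro in place of hydrogen on the methyl group, where the earlier compounds offered only a step with no fluoro group in it. Measured against the compound with hydrogen on that ring carbon, the record gives a number 0.20 log units lower from compound 1 to compound 3 (within the scatter) for fluoromethyl in place of hydrogen, so hydrogen, methyl and fluoromethyl at this position all stand within the scatter of one another in this assay and the position has yet to show a step beyond it. No supporting information bears on why the fluoro step comes out at this size, and the size alone offers no explanation of it.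

Open, on these data alone, is whether difluoromethyl, trifluoromethyl, an aminomethyl group, a carboxylic acid or a longer chain on this ring carbon would take the number beyond the scatter in this assay. Also open is whether a fluoro group in place of hydrogen elsewhere on the shared core would give a step of similar size, since the three compounds shown carry this change at one place only.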